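The source may hold more compounds than are shown below. What is called first, only, known or untested is meant among the compounds shown, and "the series" means these compounds.

Compound 1 `O=C(/C=C/c1cccc(NC(=O)c2ccccc2Br)c1)c1nc2ccccc2[nH]1` is an amide in which a 2-bromophenyl group sits on the carbonyl carbon. Going by the values given here, in a functional assay on MCF7 cells (Homo sapiens) for antiproliferative activity, read by MTT assay, with a stated time of 48 h (a higher number here means a weaker inhibitor, a lower number a stronger inhibitor), compound 1 gives 4520 nM, the lowest of the three numbers measured so far. Its nearest neighbour is compound 2 `O=C(Nc1cccc(/C=C/C(=O)c2nc3ccccc3[nH]2)c1)c1cccc(Br)c1`, which in this assay gives 5210 nM; the step of a 1.2-fold higher number from compound 1 to compound 2 (0.06 log units; within the scatter) lies within the scatter. Compound 3 `COc1cccc(C(=O)Nc2cccc(/C=C/C(=O)c3nc4ccccc4[nH]3)c2)c1` gives 17800 nM in this assay, and the step of a 3.9-fold higher number from compound 1 to compound 3 (0.60 log units; beyond the scatter) is a modest weakening, as is a 3.4-fold higher number from compound 2 to compound 3 (0.53 log units; beyond the scatter).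

Compound 4 `O=C(Nc1cccc(/C=C/C(=O)c2nc3ccccc3[nH]2)c1)c1cc(Cl)cc(Cl)c1` differs from compound 1 in one place: 3,5-dichlorophenyl in place of 2-bromophenyl on a carbonyl carbon. Among the compounds with values here, the steps that bear on this change are those from compound 1 to compound 2 and to compound 3: moving a bromine around the ring changed little, while swapping a halogen for methoxy weakened the compound. Compound 4 keeps halogens on the ring, so no step beyond the scatter is expected in this assay; the expected step is a 1.0-fold lower number from compound 1 to compound 4 (0.00 log units; within the scatter). Compound 4 is therefore estimated at 4500 nM, with a range from 2000 nM to 12000 nM.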

Compound 4, half-maximal inhibitory concentration: > 100000 nM
Compound 4: no number, only a limit (the forecaster's own chance of this, stated with the estimate: 5%); middle value at least 22-fold (1.34 log units) from the limit.
By their numbers in this assay, from the lowest: compounds 1 and 2 (each within the scatter of the next); then compound 3. At a limit, above all of these: compound 4.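

In this assay compound 4 is held only by a limit, not a number: the limit of > 100000 nM in this assay, at which 1 of the 4 values shown sits. The change to 3,5-dichlorophenyl gives an at least 22-fold higher number from compound 1 to compound 4 (1.34 log units; beyond the scatter) and an at least 19-fold higher number from compound 2 to compound 4 (1.28 log units; beyond the scatter), so a halogen on the ring at this carbonyl carbon does not by itself keep the level of compound 1 and compound 2. It also gives an at least 5.6-fold higher number from compound 3 to compound 4 (0.74 log units; beyond the scatter), so the methoxy group of compound 3 is no longer the weakest substitution seen here.

The compounds shown do not separate chlorine in place of bromine from two ring substituents in place of one, and how far compound 4 truly lies stays unknown. Going by these compounds, how a 3-chlorophenyl group, or a ring carrying an amine or a carboxylic acid, would behave in this assay also stays open.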